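The compounds below may be only part of what the source reports. "The series", "measured", "known", "first", "only" and "open" are said of these compounds alone.

Working notes on the series: in a functional assay on SK-OV-3 cells (Homo sapiens) for inhibition, read by CCK-8 assay, with a stated time of 70 h (on this read-out higher numbers stand for weaker inhibition and lower numbers for stronger inhibition), compound 1 (`c1ccc(COc2ccc(OCCOCCNC3CCCC3)cc2)cc1`) gives 24800 nM, the higher of the two numbers measured so far, while compound 2 (`c1ccc(COc2ccc(OCCOCCNC3CCCCC3)cc2)cc1`) gives 7370 nM. Compound 3 (`c1ccc(COc2ccc(COc3ccc(OCCOCCNC4CCCC4)cc3)cc2)cc1`) has not yet been measured. It keeps the core of compound 1 and differs by one change: benzyloxy in place of hydrogen on an aromatic carbon. Among the measured compounds shown here, only one measured step is available, a 3.4-fold lower number from compound 1 to compound 2 (0.53 log units; beyond the scatter), a modest change beyond the scatter. That step lies at the amine nitrogen rather than at the aromatic carbon changed here, so it bears on compound 3 only indirectly. For the measured compounds named here, no measured compound carries a substituent at this aromatic carbon, and the direction is therefore an expectation with little support. A step of similar size towards a lower number in this assay is expected, although a result within the scatter remains possible. The estimate is a 2.8-fold lower number from compound 1 to compound 3 (0.44 log units; beyond the scatter), as an expected change. For compound 3 the expected value is 9000 nM, with an estimated range of 2500 nM to 30000 nM.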

Compound 3, half-maximal inhibitory concentration: 10000 nM
For compound 3 the middle estimate is 1.1-fold (0.05 log units) below the measured one; measured number inside the range.
By their numbers in this assay, from the lowest: compounds 2 and 3 (each within the scatter of the next); then compound 1.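

In this assay, among the compounds shown here, the aromatic carbon para to a large group, which no earlier compound varied, responds to substitution: benzyloxy in place of hydrogen gives a 2.5-fold lower number from compound 1 to compound 3 (0.39 log units; beyond the scatter). This is a second site at which a single change lowers the number beyond the scatter, in the same direction as the amine nitrogen change, which gives a 3.4-fold lower number from compound 1 to compound 2 (0.53 log units; beyond the scatter). The step also shows that a group of 8 heavy atoms, bringing one more six-membered aromatic ring of carbon only, can enter here without raising the number, although nothing available accounts for the shift at this position.

Going by these compounds, whether the step depends on the whole benzyloxy group or on only part of it remains open, and a methoxy or hydroxy group on the same carbon would help separate the two. On these data alone, it is also open whether the benzyloxy and cyclohexyl changes add together, a question that only a compound carrying both on the core of compound 1 could answer.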